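The source may hold more compounds than are shown below. What is called first, only, known or untested is meant among the compounds shown, and "the series" means these compounds.

Compound 1 `O=C(Nc1ccc(Cl)c(-c2nnc3c(Cl)cccn23)c1)c1ccc(F)cc1Cl` is one of three amides built on the same core. In a functional assay on U-251 cells (Homo sapiens) for antiproliferative activity, read by MTT assay, with a stated time of 72 h (on this read-out lower numbers stand for stronger inhibition and higher numbers for weaker inhibition), compound 1 gives > 100000 nM, which is a limit of the assay and not a number. Compound 2 `O=C(Nc1ccc(Cl)c(-c2nnc3c(Cl)cccn23)c1)c1ccccn1` is the only one of the three that returns a number: in this assay compound 2 gives 79000 nM. Compound 3 `Cc1cc(Cl)ccc1C(=O)Nc1ccc(Cl)c(-c2nnc3c(Cl)cccn23)c1` again sits at a limit; in this assay compound 3 gives > 100000 nM. The step of an at least 1.2-fold lower number from compound 1 to compound 2 (0.10 log units; that floor lies within the scatter) and the step of an at least 1.2-fold higher number from compound 2 to compound 3 (0.10 log units; that floor lies within the scatter) both have floors within the scatter, and the step that the two limits leave unreadable from compound 1 to compound 3 cannot be read at all because of the limit of > 100000 nM in this assay, at which 2 of the 3 values shown sit. Compound 4 `O=C(Nc1ccc(Cl)c(-c2nnc3c(Cl)cccn23)c1)c1c(F)cccc1Cl` differs from compound 1 by 2-chloro-6-fluorophenyl in place of 2-chloro-4-fluorophenyl on a carbonyl carbon. Within the data shown here, none of the measured steps makes this change; they show only that every exchange of the group on the carbonyl carbon so far has left the value at or near the limit. Compound 4 is therefore expected to stay in that region, with an estimated step of a number no higher from compound 1 to compound 4 (the limit leaves the size open). The estimate for compound 4 is 100000 nM, within 40000 nM to 300000 nM.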

Compound 4, half-maximal inhibitory concentration: > 100000 nM
Compound 4: no number, only a limit; the forecaster's own chance of this, stated with the estimate: 70%; the middle value sits exactly at the limit.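

Placing 2-chloro-6-fluorophenyl on the carbonyl carbon in place of 2-chloro-4-fluorophenyl, with the same atoms joined differently, still gives only a limit and not a number for compound 4, so this exchange opens no measurable difference from compound 1. The steps to compound 4 from compound 1 and from compound 3 cannot be read because both ends of each are limits: the limit of > 100000 nM in this assay, at which 3 of the 4 values shown sit. In this assay the exchange of pyridin-2-yl for 2-chloro-6-fluorophenyl gives an at least 1.2-fold higher number from compound 2 to compound 4 (0.10 log units; that floor lies within the scatter), so compound 2 remains the only one of the four with a number, and its floor does not separate it from compound 4.

On these data alone, how far compounds 1, 3 and 4 lie past the limit remains open. So does whether an amine or a carboxylic acid on the phenyl ring would bring a value clear of it.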